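From compound 1 to compound 3: notes on the series

A few compounds are considered here, and "the series" means these few. Any claim that something is new, unique, unknown or untested is made for them only; others in the source may bear on it.

Measured in a functional assay on PC-3M cells (Homo sapiens) for antiproliferative activity, read by microscopy, with a stated time of 24 h; on this read-out lower numbers stand for stronger inhibition and higher numbers for weaker inhibition:
- compound 1 `O[C@H]1CC[C@H](Nc2ncnc3c2c(-c2ccccc2)c(-c2ccccc2)n3Cc2ccccc2)CC1`: > 20000 nM
- compound 2 `COc1ccc(-c2c(-c3ccc(OC)cc3)n(Cc3ccccc3)c3ncn([C@@H]4CCCC[C@H]4O)c(=N)c23)cc1`: > 20000 nM

Both entries are limits of the assay and not numbers. Compound 1 stands at > 20000 nM, which is a limit. Compound 2 stands at > 20000 nM, which is also a limit. Taken together, the series so far shows (the limit of > 20000 nM in this assay, at which 2 of the 2 values shown sit).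

Compound 3 `OCCCNc1ncnc2c1c(-c1ccccc1)c(-c1ccccc1)n2Cc1ccccc1` has not yet been measured. It keeps the core of compound 1 and changes one group, 3-hydroxypropyl in place of 4-hydroxycyclohexyl on a nitrogen on an aromatic ring. The entering group has no ring.

Among the compounds with values here, no step between measured compounds is available to size this change, so the expectation rests on the limit alone. In this assay, no change beyond the usual scatter is expected, and another limit is the most likely report. The expected step is a number no higher from compound 1 to compound 3 (the limit leaves the size open). The estimate for compound 3 is 20000 nM. The expected range for compound 3 runs from 8000 nM to 50000 nM.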

Compound 3, half-maximal inhibitory concentration: > 20000 nM
Compound 3: no number, only a limit; the forecaster's own chance of this, stated with the estimate: 75%; the middle value lies on the limit itself.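

In this assay no step can be read between compound 1 and compound 3, since both entries are limits of the assay and not numbers: the limit of > 20000 nM in this assay, at which 3 of the 3 values shown sit.

The compounds shown leave open whether 3-hydroxypropyl in place of 4-hydroxycyclohexyl changes the activity at all, and how far any of the three lies past the limit.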